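Chloro for fluoro at two different places in one indole series

The compounds below may be only part of what the source reports. "The series", "measured", "known", "first", "only" and "open" are said of these compounds alone.

Of the compounds shown here, three have been tested in an ADME assay on MCF7 cells (Homo sapiens) for cytotoxicity, read by MTT assay, with a stated time of 48 h; a higher number here means a weaker inhibitor, a lower number a stronger inhibitor. Compound 1 `Fc1ccc(-c2[nH]c3cc(Cl)ccc3c2Cn2ccnc2)cc1` gives 41500 nM. Compound 2 `Clc1ccc(-c2[nH]c3cc(Cl)ccc3c2Cn2ccnc2)cc1` differs from it by chloro in place of fluoro on an aromatic carbon, on an aromatic carbon of a six-membered aromatic ring of carbon only, para to a large group. For compound 2 this assay reports only a limit, > 1000000 nM, which is the limit of > 1000000 nM in this assay, at which 1 of the 3 values shown sits. The resulting step is an at least 24-fold higher number from compound 1 to compound 2 (1.38 log units; beyond the scatter). Compound 3 `COc1ccc(-c2[nH]c3cc(F)ccc3c2Cn2cncn2)cc1` gives 325000 nM; the difference between its core and the core of compound 1 is not broken down here.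

Compound 4 `COc1ccc(-c2[nH]c3cc(Cl)ccc3c2Cn2cncn2)cc1` has not yet been measured. It differs from compound 3 by chloro in place of fluoro on an aromatic carbon, here on a ring that is part of a fused or bridged system of two rings, meta to a fused ring and para to a fused ring. It is the same kind of change as that from compound 1 to compound 2, not the same change. Beside the large step measured from compound 1 to compound 2, the step from compound 3 to compound 4 is expected to be smaller, a 1.7-fold higher number from compound 3 to compound 4 (0.23 log units; within the scatter), because compound 3 already gives 325000 nM, a higher number than that of compound 1, and the place differs. Compound 4 is therefore estimated at 550000 nM, between 150000 nM and 1500000 nM.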

Compound 4, half-maximal inhibitory concentration: 14400 nM
Beside the measured number, compound 4's estimate is 38-fold (1.58 log units) above it, and the stated range ends above it.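

In this assay, chloro in place of fluoro gives a 23-fold lower number from compound 3 to compound 4 (1.35 log units; beyond the scatter), so on this core the swap goes with a stronger inhibitor, and the two steps point in opposite directions by far more than the scatter of two such steps: the same change on two cores in this assay, an at least 24-fold higher number (1.38 log units; beyond the scatter) from compound 1 to compound 2 and a 23-fold lower number (1.35 log units; beyond the scatter) from compound 3 to compound 4, at least 540-fold (2.73 log units) apart, beyond the scatter of two such steps The earlier step rests on compound 2, whose > 1000000 nM is a limit of the assay and not a number: the limit of > 1000000 nM in this assay, at which 1 of the 4 values shown sits. The direction of this swap therefore cannot simply be carried from one core to the other in this series, but the two pairs differ both in where the swap sits and in the rest of the core, and the compounds shown do not tell these two apart.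

On these data alone, it remains open how the swap behaves when both places are tried on one shared core, which would separate place from core. As far as these compounds go, it is also open whether a bromo group or a nitrile in place of the chloro of compound 4 would keep its lower number.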